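This account rests on a few compounds, and the source may have more. Where it says the series, first, only, none or still open, it means among the compounds named here.

Working notes on the series. Compound 3, `Cc1nc(-c2cccc(Cl)c2)sc1COc1ccc2c(c1)OCC2CC(=O)O`, gives 43% in a functional assay on CHO cells for agonist activity at Free fatty acid receptor 1 (Homo sapiens), read by FLIPR and calcium flux, tested at 100 nM; a lower number here means a weaker effect, a higher number a stronger effect of the compound at the concentration tested; it stands second highest of the three numbers, with compound 1, `Cc1nc(-c2cccs2)sc1COc1ccc2c(c1)OCC2CC(=O)O`, giving 35.2% and compound 2, `Cc1ccc(-c2nc(C)c(COc3ccc4c(c3)OCC4CC(=O)O)s2)cc1`, giving 54.9%. The step from compound 1 to compound 3 is a number 7.8 percentage points higher from compound 1 to compound 3 (within the scatter), the step from compound 2 to compound 3 is a number 11.9 percentage points lower from compound 2 to compound 3 (beyond the scatter), and the step from compound 1 to compound 2 is a number 19.7 percentage points higher from compound 1 to compound 2 (beyond the scatter).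

Compound 4, `Cc1nc(-c2ccc(C(F)(F)F)cc2)sc1COc1ccc2c(c1)OCC2CC(=O)O`, is not yet measured. It differs from compound 3 as follows: 4-(trifluoromethyl)phenyl in place of 3-chlorophenyl on an aromatic carbon. Among the measured compounds shown here, the steps that bear on this are the two that end at compound 3, both exchanges of the aryl group on the same aromatic carbon; the larger one, a number 11.9 percentage points lower from compound 2 to compound 3 (beyond the scatter), shows that an aryl exchange here can move the read-out beyond the scatter, the smaller, a number 7.8 percentage points higher from compound 1 to compound 3 (within the scatter), that it need not. Since compound 4 carries a 4-substituted phenyl like compound 2, a modest step upward in this assay is expected for compound 4, roughly a number 6 percentage points higher from compound 3 to compound 4 (within the scatter). The estimate for compound 4 is therefore 49%, with a range from 32% to 66%.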

Compound 4, a percentage reported as activity, at one concentration (the size of the read-out at that concentration, not a potency): 50.4%
Estimate against measurement, compound 4: 1.4 percentage points below; the measured number falls inside the stated range.
By their numbers in this assay, from the lowest: compounds 1, 3, 4 and 2 (each within the scatter of the next, the first and the last beyond it).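

In this assay, among the compounds shown here, the first exchange of the substituent on the phenyl ring alone, trifluoromethyl for methyl, gives a number 4.5 percentage points lower from compound 2 to compound 4 (within the scatter), so the two groups are not separated at this site. The exchange of 3-chlorophenyl for 4-(trifluoromethyl)phenyl gives a number 7.4 percentage points higher from compound 3 to compound 4 (within the scatter), while a number 15.2 percentage points higher from compound 1 to compound 4 (beyond the scatter) adds a second aryl group, after 4-methylphenyl, that stands clear of thiophen-2-yl; 3-chlorophenyl goes against any rule that all phenyl groups do so. No measurement at hand bears on the reason for these steps.

From the compounds shown here alone, the effect of substituent place on the phenyl ring stays open, as compound 3 and compound 4 differ in both the substituent and its place. Also open, going by these compounds, is how an amine, a methoxy group or a carboxylic acid on that ring would read in this assay.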